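Swapping the cyclopentyloxy group for a dimethoxyphenyl ring

The source may hold more compounds than are shown below. What is called first, only, known or untested is meant among the compounds shown, and "the series" means these compounds.

Measured so far:
Compound 1, `CC(C(=O)NCc1ccc(C(F)(F)F)cc1N1CCC(C)(C)CC1)c1ccc(NS(C)(=O)=O)c(F)c1`, 1.3 nM
Compound 2, `CC(C(=O)NCc1ccc(C(F)(F)F)cc1OC1CCCC1)c1ccc(NS(C)(=O)=O)c(F)c1`, 0.6 nM

Both compounds were tested in an assay on CHO cells for antagonist activity at transient receptor potential cation channel subfamily V member 1 (Homo sapiens), read by FLIPR; on this read-out higher numbers stand for weaker inhibition and lower numbers for stronger inhibition. For the measured compounds named here, compound 2 has the lowest of the two numbers, and the only step measured so far, a 2.2-fold lower number from compound 1 to compound 2 (0.34 log units; beyond the scatter), separates it from compound 1.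

Compound 3, `COc1cc(OC)cc(-c2cc(C(F)(F)F)ccc2CNC(=O)C(C)c2ccc(NS(C)(=O)=O)c(F)c2)c1`, carries a different group on the same aromatic carbon: 3,5-dimethoxyphenyl in place of cyclopentyloxy on an aromatic carbon. Going by the values given here, no measured step covers this exact exchange; the single step from compound 1 to compound 2 only shows that replacing one group at this position by another moved the number modestly. The entering group is larger and aromatic, so a small loss of potency seems more likely than a gain, but the evidence is thin. Compound 3 is therefore expected to give 1.5 nM, between 0.4 nM and 6 nM, which corresponds to an estimated step of a 2.5-fold higher number from compound 2 to compound 3 (0.40 log units; beyond the scatter).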

Compound 3, inhibition constant: 5.8 nM
For compound 3 the middle estimate is 3.9-fold (0.59 log units) below the measured one; measured number inside the range.
By their numbers in this assay, from the lowest: compound 2; then compound 1; then compound 3.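

In this assay, placing 3,5-dimethoxyphenyl on this aromatic carbon, ortho to a large group and meta to a trifluoromethyl group, gives a 9.7-fold higher number from compound 2 to compound 3 (0.99 log units; beyond the scatter) and a 4.5-fold higher number from compound 1 to compound 3 (0.65 log units; beyond the scatter) as well. The group at this position can therefore shift the number by more than the first exchange suggested, and an aromatic ring here gives the weakest inhibition of the three compounds, though compound 3 still reads 5.8 nM in this assay and so keeps clear activity. Nothing at hand gives a reason for this order.

Going by these compounds, whether the loss belongs to the aromatic ring itself or to its two methoxy groups stays open, and a plain phenyl ring would help to separate the two. How a small ether such as methoxy would behave on this carbon is also unknown.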